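Adding 4-chlorophenyl to the side chain of compound 2

The source may report more compounds than this note shows. Statements on the series, on what has been measured and on what is new or still open speak of the compounds shown alone.

Measured so far in a functional assay on DU-145 cells (Homo sapiens) for cytotoxicity, read by trypan blue exclusion, with a stated time of 96 h; on this read-out lower numbers stand for stronger inhibition and higher numbers for weaker inhibition
- compound 1 `COc1ccc(CS(=O)(=O)/C=C/c2c(OC)cc(O)cc2OC)cc1[N+](=O)[O-]` gives 5000 nM
- compound 2 `COC(=O)CNc1cc(CS(=O)(=O)/C=C/c2c(OC)cc(OC)cc2OC)ccc1OC` gives 100 nM

Of these two, compound 2 has the lower number and so shows the stronger inhibition. The gap to compound 1 lies well beyond the scatter of the measurement.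

Compound 3 `COC(=O)C(Nc1cc(CS(=O)(=O)/C=C/c2c(OC)cc(OC)cc2OC)ccc1OC)c1ccc(Cl)cc1` departs from compound 2 in one place (4-chlorophenyl in place of hydrogen on a saturated chain carbon bound to a carbonyl carbon and a nitrogen on an aromatic ring): 4-chlorophenyl in place of hydrogen on a saturated chain carbon bound to a carbonyl carbon and a nitrogen on an aromatic ring.

Going by the values given here, no measured pair shows a change at this carbon, so the expectation for this assay is a judgement. A moderate rise toward weaker inhibition, beyond the scatter, is expected, although a step within the scatter remains possible. The estimated change is a 3.0-fold higher number from compound 2 to compound 3 (0.48 log units; beyond the scatter) in that direction. Compound 3 is expected at 300 nM (estimated range 60 nM to 1500 nM).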

Compound 3, half-maximal inhibitory concentration: 400 nM
Estimate against measurement, compound 3: 1.3-fold (0.12 log units) below, and the stated range covers the measured number.
By their numbers in this assay, from the lowest: compound 2; then compound 3; then compound 1.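

In this assay, going by these compounds alone, the saturated chain carbon bound to a carbonyl carbon and a nitrogen on an aromatic ring is the first place where a single change can be read, and it carries a cost (a 4.0-fold higher number from compound 2 to compound 3 (0.60 log units; beyond the scatter)). The step is modest but beyond the scatter, so adding 4-chlorophenyl here weakens inhibition without abolishing it, and compound 3 still gives 400 nM. Nothing available explains why the number rises.

The compounds shown leave open whether a methyl or an unsubstituted phenyl on this carbon would bring a smaller step, and so whether the size of the group or the chlorine matters. They also leave open how a carboxylic acid in place of the methyl ester would read at this position, with or without the 4-chlorophenyl.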